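This account rests on a few compounds, and the source may have more. Where it says the series, first, only, none or still open, it means among the compounds named here.

Working notes on the series in this assay.

Compound 1 `COc1cc(-c2cc(/C=C/C(=O)c3ccc(N)cc3)[nH]n2)cc(OC)c1OC` carries an amino group on the aromatic ring bound to the carbonyl; in a functional assay on SF-268 cells (Homo sapiens) for inhibition, read by sulforhodamine B assay, with a stated time of 48 h (a lower number here means that less compound is tolerated, a higher number that more compound is tolerated), compound 1 gives 9160 nM. Compound 2 `COc1ccc(C(=O)/C=C/c2cc(-c3cc(OC)c(OC)c(OC)c3)n[nH]2)cc1` has a methoxy in place of that amino on an aromatic carbon. In this assay compound 2 reaches only the limit > 100000 nM, which is a bound of the measurement and not a number (the limit of > 100000 nM in this assay, at which 1 of the 2 values shown sits). The step is an at least 10-fold higher number from compound 1 to compound 2 (1.03 log units; beyond the scatter), so compound 2 stands at the top of the series, where no more than a limit is known.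

Compound 3 `COc1cc(-c2cc(/C=C/C(=O)c3ccc(F)c(F)c3)[nH]n2)cc(OC)c1OC` is not yet measured. Relative to compound 2 it shows (3,4-difluorophenyl in place of 4-methoxyphenyl on a carbonyl carbon). Among the compounds with values here, no measured step covers an exchange of a methoxy for fluorines, so the only step that bears on it is the one from the amino compound to the methoxy compound, which was large and went towards the limit. With compound 2 already at the limit, compound 3 is expected to stay high but may return below it, and is estimated at 50000 nM, ranging from 10000 nM to 150000 nM. The estimate for compound 3 means an expected step of an at least 2.0-fold lower number from compound 2 to compound 3 (0.30 log units; that floor lies within the scatter).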

Compound 3, concentration lethal to 50% of the cells: > 100000 nM
Compound 3 ended at the assay's limit; the forecaster's own chance of this, stated with the estimate: 40%; middle value at least 2.0-fold (0.30 log units) away from the limit.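

In this assay compound 3 gives > 100000 nM, which is a limit of the assay and not a number. Exchanging the 4-aminophenyl on a carbonyl carbon for 3,4-difluorophenyl gives an at least 10-fold higher number from compound 1 to compound 3 (1.03 log units; beyond the scatter), so the large step at this position is no longer tied to methoxy alone: two different replacements of the 4-aminophenyl now end at the same limit. Compound 1 remains the only compound shown with a readable number, and the step between compound 2 and compound 3 cannot be read, so the series gives no order between 4-methoxyphenyl and 3,4-difluorophenyl: the limit of > 100000 nM in this assay, at which 2 of the 3 values shown sit.

Open, on these data alone, is whether the amino group itself sets the lower number of compound 1, or whether a hydroxy, a dimethylamino or an acetamido group on the same ring would also give a value under the limit. Also open, as far as these compounds go, is how far past the limit compound 2 and compound 3 lie, and whether either differs from the other in this assay.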